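Phenyl to pyridin-4-yl in compound 2

The compounds below may be only part of what the source reports. "The series", "measured", "known", "first", "only" and "open" are said of these compounds alone.

In a functional assay on HT-29 cells (Homo sapiens) for cytotoxicity, read by MTT assay, with a stated time of 72 h (a higher number here means a weaker inhibitor, a lower number a stronger inhibitor), compound 1 (`O=C(CN1CCN(c2nnc(Cc3ccncc3)c3ccccc23)CC1)Nc1ccc(Br)cc1`) gives 1990 nM while compound 2 (`Cc1cccc(Cl)c1NC(=O)CN1CCN(c2nnc(Cc3ccccc3)c3ccccc23)CC1`) gives 53600 nM and so stands highest of the two, with a gap beyond the scatter. Compound 3 (`Cc1cccc(Cl)c1NC(=O)CN1CCN(c2nnc(Cc3ccncc3)c3ccccc23)CC1`) differs from compound 2 in one place (pyridin-4-yl in place of phenyl on a saturated chain carbon bound to an aromatic carbon): pyridin-4-yl in place of phenyl on a saturated chain carbon bound to an aromatic carbon. Among the compounds with values here, no measured pair shows this change alone. Within the data shown here, compound 1 also carries pyridin-4-yl, and its value of 1990 nM is the only measured guide, though two compounds cannot show how much of the gap goes with this group. A step to a lower number, beyond the scatter but short of that gap, is therefore expected in this assay and estimated as a 6.0-fold lower number from compound 2 to compound 3 (0.77 log units; beyond the scatter) for this change. For compound 3 the estimated value is 9000 nM with an expected range from 2000 nM to 40000 nM as the likely span.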

Compound 3, half-maximal inhibitory concentration: 22600 nM
Beside the measured number, compound 3's estimate is 2.5-fold (0.40 log units) below it; measured number inside the range.
By their numbers in this assay, from the lowest: compound 1; then compound 3; then compound 2.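

In this assay, pyridin-4-yl in place of phenyl on a saturated chain carbon bound to an aromatic carbon now has a measured effect of its own: a modest step, a 2.4-fold lower number from compound 2 to compound 3 (0.38 log units; beyond the scatter), with the rest of the molecule unchanged. With pyridin-4-yl held constant, 2-chloro-6-methylphenyl in place of 4-bromophenyl on an amide-type nitrogen gives a large step, an 11-fold higher number from compound 1 to compound 3 (1.06 log units; beyond the scatter), so the earlier gap is not tied to the pyridin-4-yl change alone.

From the compounds shown here alone, it remains open whether pyridin-2-yl, pyridin-3-yl or cyclohexyl on that chain carbon would give a similar step. It is also open whether the phenyl to pyridin-4-yl step keeps its size with 4-bromophenyl on the amide-type nitrogen, since no phenyl partner for compound 1 is shown. No measurement at hand gives a reason for either step.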